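Swapping the Aryl Group on a Piperazine Thiosemicarbazone

The source may hold more compounds than are shown below. What is called first, only, known or untested is meant among the compounds shown, and "the series" means these compounds.

Two measured compounds share a core in which a thiosemicarbazone links an oxindole to a piperazine carrying an aryl group. In a functional assay on HCT-116 cells (Homo sapiens) for inhibition, read by MTT assay, with a stated time of 72 h (on this read-out lower numbers stand for stronger inhibition and higher numbers for weaker inhibition), compound 1 `COc1ccc2c(c1)/C(=N/NC(=S)N1CCN(c3ccccc3)CC1)C(=O)N2` gives 9530 nM. Its partner, compound 2 `Cc1ccccc1N1CCN(C(=S)N/N=C2\C(=O)Nc3ccc(Cl)cc32)CC1`, gives 4910 nM in this assay. On the two numbers shown, compound 2 sits alongside compound 1 within the usual scatter of repeated measurements, so neither can be called the stronger inhibitor on this evidence.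

The unmeasured compound 3 `O=C1Nc2ccc(Cl)cc2/C1=N/NC(=S)N1CCN(c2ccc([N+](=O)[O-])cc2)CC1` differs from compound 2 in one place: 4-nitrophenyl in place of 2-methylphenyl on an amine nitrogen in a ring. For the measured compounds named here, no pair of measured compounds that differ in a single place is available, so the size of this step cannot be read from the data; the only guide is that changing the aryl group between compound 1 and compound 2 moved the number by less than the scatter. The step from compound 2 to compound 3 is therefore expected to be a 1.0-fold higher number from compound 2 to compound 3 (0.01 log units; within the scatter), that is, no change beyond the scatter. Compound 3 is estimated at 5000 nM, within a range from 1500 nM to 16000 nM.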

Compound 3, half-maximal inhibitory concentration: 12000 nM
Estimate against measurement, compound 3: 2.4-fold (0.38 log units) below; the measured number falls inside the stated range.
By their numbers in this assay, from the lowest: compounds 2, 1 and 3 (each within the scatter of the next, the first and the last beyond it).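

For the compounds shown here, the single change of 4-nitrophenyl in place of 2-methylphenyl gives a 2.4-fold higher number from compound 2 to compound 3 (0.39 log units; beyond the scatter) in this assay, and this is the first step that can be read at one place with everything else held the same. It shows that inhibition in these cells responds to the aryl group on this ring nitrogen, though only modestly, with the higher number meaning weaker inhibition for compound 3. The data give no explanation for this step, so why the swap weakens inhibition remains unknown.

The swap both removes a methyl group and adds a nitro group at a different place on the phenyl ring, so the two compounds cannot show which of these changes matters, or whether both do. On these data alone, it also remains open how this position would respond to a quite different group, such as a 4-aminophenyl, a phenyl ring bearing a carboxylic acid, or a longer chain in place of the aryl ring, and whether any of these would move the number lower rather than higher.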